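Shortening the chain and swapping the substituent on a succinimide

The source may hold more compounds than are shown below. What is called first, only, known or untested is meant among the compounds shown, and "the series" means these compounds.

Measured compounds:
- Compound 1, `COc1ccc(CC2CC(=O)N(c3ccccc3C(=O)OCC3CCCN(CCCc4ccccc4)C3)C2=O)cc1`, gives 38900 nM in an in vitro functional assay on HEK ts201 cells for antagonist activity at Neuronal acetylcholine receptor; alpha4/beta2 (Homo sapiens), read by fluorescence and calcium flux; a higher number here means a weaker inhibitor, a lower number a stronger inhibitor.
- Compound 2, `CN1CCCC(COC(=O)c2ccccc2-c2ccccc2)C1`, gives 6920 nM in this assay.
- Compound 3, `O=C(OCC1CCCN(CCCc2ccccc2)C1)c1ccccc1N1C(=O)CC(CCc2ccccc2)C1=O`, gives 5130 nM in this assay.

Compound 3 has the lowest number of the three, though its gap to compound 2 lies within the scatter; only its gap to compound 1 stands beyond it. Going by the values given here, that gap is the one step between compounds differing in a single place: a 7.6-fold lower number from compound 1 to compound 3 (0.88 log units; beyond the scatter).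

Compound 4, `O=C(OCC1CCCN(CCCc2ccccc2)C1)c1ccccc1N1C(=O)CC(Cc2ccc(Cl)cc2)C1=O`, is not yet measured in this assay. It differs from compound 3 in one place: 4-chlorophenyl in place of benzyl on a saturated chain carbon bound to a saturated ring carbon. In effect the chain that carries the aromatic ring is cut back by one carbon, as in compound 1, while the ring now carries a chlorine rather than the methoxy group of compound 1.

Among the compounds with values here, only the step from compound 1 to compound 3 bears on this, and it covers the chain length, not the chlorine. Since compound 4 returns to the shorter chain, the number is expected to move back up toward that of compound 1, though by how much the chlorine alters this cannot be told from these data. The expected step is a 2.3-fold higher number from compound 3 to compound 4 (0.37 log units; beyond the scatter), giving an estimated 12000 nM for compound 4 in this assay, with a range from 4000 nM to 40000 nM.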

Compound 4, half-maximal inhibitory concentration: 10700 nM
The estimate for compound 4 lay 1.1-fold (0.05 log units) above the measured number; measured number inside the range.
By their numbers in this assay, from the lowest: compounds 3, 2 and 4 (each within the scatter of the next, the first and the last beyond it); then compound 1.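

Set against compound 1, compound 4 keeps the same one-carbon link to the aromatic ring and changes only the ring substituent, and this gives a 3.6-fold lower number from compound 1 to compound 4 (0.56 log units; beyond the scatter) in this assay. So at this position, the group on the aromatic ring alone can shift the number beyond the scatter, something the earlier step could not show, since it replaced 4-methoxybenzyl with an unsubstituted phenethyl and so changed both the ring substituent and the chain. The change from phenethyl to 4-chlorobenzyl gives a 2.1-fold higher number from compound 3 to compound 4 (0.32 log units; beyond the scatter), which places compound 4 between compound 3 and compound 1, but the shorter chain and the chlorine arrive together in this step, and nothing available gives a measured reason for the size of either step.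

As far as these compounds go, how much of that rise belongs to the chain and how much to the chlorine stays open, and a plain benzyl group with no ring substituent at this place would be needed to divide it. Also open, from the compounds shown here alone, is whether a longer chain carrying the 4-chlorophenyl ring, or an amine or a carboxylic acid on that ring, would move the number further in either direction.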